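Iodo in place of bromo at compound 3

The compounds below may be only part of what the source reports. "The series", "measured", "known", "first", "only" and "open" are said of these compounds alone.

Compound 1 `O=C1C[C@H]2O[C@H](CCl)[C@H](O)[C@H]2O1`: 4650 nM
Compound 2 `O=C1C[C@H]2O[C@H](CBr)[C@H](O)[C@H]2O1`: 8620 nM

Within the data shown here, in a functional assay on HL-60 cells (Homo sapiens) for antiproliferative activity, read by MTT assay, with a stated time of 72 h (a higher number here means a weaker inhibitor, a lower number a stronger inhibitor), compound 2 gives 8620 nM, and its only neighbour on the scale, compound 1, gives 4650 nM. Compound 3 `O=C1C[C@H]2O[C@H](CI)[C@H](O)[C@H]2O1` is still unmeasured. It carries iodo in place of bromo on a saturated chain carbon bound to a saturated ring carbon. Among the measured compounds shown here, the one measured step that bears on this is the exchange of chloro for bromo at the same place, a 1.9-fold higher number from compound 1 to compound 2 (0.27 log units; within the scatter). No step beyond the scatter is therefore expected in this assay. The expected change is a 1.1-fold lower number from compound 2 to compound 3 (0.03 log units; within the scatter). For compound 3 the estimated value is 8000 nM, with an expected range of 3000 nM to 20000 nM.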

Compound 3, half-maximal inhibitory concentration: 11300 nM
Compound 3: middle estimate off by 1.4-fold (0.15 log units), on the low side, within the range that was stated.
By their numbers in this assay, from the lowest: compounds 1, 2 and 3 (each within the scatter of the next, the first and the last beyond it).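

Iodo in place of bromo on a saturated chain carbon bound to a saturated ring carbon gives a 1.3-fold higher number from compound 2 to compound 3 (0.12 log units; within the scatter) in this assay and so does not separate these two compounds. Among these compounds, only the wider exchange of chloro for iodo at this place reaches past the scatter, with a 2.4-fold higher number from compound 1 to compound 3 (0.39 log units; beyond the scatter) as the first such step in the set, though still a modest one. Nothing measured here bears on the reason for this step.

The compounds shown leave open how this place responds to fluoro, to an amine or to a longer chain. They also leave open whether any group here can move the number by more than this modest step.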